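This account rests on a few compounds, and the source may have more. Where it says the series, first, only, none or still open, it means among the compounds named here.

Compound 2 `Cc1ccc(-c2c3ccc4ccccc4c3nc3c2c(C)nc2c4ccccc4ccc32)cc1` gives 68.7 ug/mL in a functional assay, read by spectrophotometry, with a stated time of 15 min; a lower number here means a stronger inhibitor, a higher number a weaker inhibitor. Among the measured compounds shown here, the only other number measured is that of compound 1 `Cc1nc2c3ccccc3ccc2c2nc3c(ccc4ccccc43)c(-c3ccccc3N)c12`, which gives 45.6 ug/mL in this assay; the step of a 1.5-fold higher number from compound 1 to compound 2 (0.18 log units; within the scatter) lies within the scatter. Compound 3 `Cc1nc2c3ccccc3ccc2c2nc3c(ccc4ccccc43)c(-c3cc(O)nc4ccccc34)c12` differs from compound 2 by 2-hydroxyquinolin-4-yl in place of 4-methylphenyl on an aromatic carbon. For the measured compounds named here, the one measured step bears on this change only in that it swaps the group on the same aromatic carbon, and it was within the scatter; the entering 2-hydroxyquinolin-4-yl has no measured precedent. The expected step in this assay is therefore a 1.2-fold lower number from compound 2 to compound 3 (0.10 log units; within the scatter), with no sure direction. Compound 3 is estimated at 55 ug/mL, between 20 ug/mL and 150 ug/mL.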

Compound 3, half-maximal inhibitory concentration: 44.8 ug/mL
Compound 3: middle estimate off by 1.2-fold (0.09 log units), on the high side, and the stated range covers the measured number.
By their numbers in this assay, from the lowest: compounds 3, 1 and 2 (each within the scatter of the next).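

In this assay the aromatic carbon opposite the ring nitrogen now carries 2-hydroxyquinolin-4-yl, and both steps to it stay within the scatter (a 1.5-fold lower number from compound 2 to compound 3 (0.19 log units; within the scatter); a 1.0-fold lower number from compound 1 to compound 3 (0.01 log units; within the scatter)). The 2-aminophenyl, 4-methylphenyl and 2-hydroxyquinolin-4-yl groups at this carbon thus give numbers that cannot be told apart, and the hydrogen-bond donor and acceptors entering with 2-hydroxyquinolin-4-yl bring no readable change from 4-methylphenyl. No available evidence accounts for this result.

As far as these compounds go, whether a carboxylic acid, a morpholine or a longer alkyl chain at this carbon would move the number beyond the scatter remains open. Also open, from the compounds shown here alone, is whether this pattern would hold with another group in place of the methyl on the shared core.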